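An Ethoxyphenyl Group Replaces Cyclopropyl on the Amine

The compounds below may be only part of what the source reports. "The series", "measured", "known", "first", "only" and "open" are said of these compounds alone.

Compound 2 `O=C1C(NC2CC2)=CC(=O)c2c1nc1n2[C@H]2OC[C@@H](O)[C@H]2OC1` carries cyclopropyl on an amine nitrogen of the shared core, and its standing in a functional assay on HeLa cells (Homo sapiens) for inhibition, read by sulforhodamine B assay (a higher number here means a weaker inhibitor, a lower number a stronger inhibitor), is known only as a limit. Compound 2 gives > 16000 nM, which is a limit and not a number. Compound 1 `O=C1C(Nc2ccccc2)=CC(=O)c2c1nc1n2[C@H]2OC[C@@H](O)[C@H]2OC1`, the phenyl counterpart, gives > 8000 nM, which is also a limit.

Compound 3 `CCOc1ccc(NC2=CC(=O)c3c(nc4n3[C@H]3OC[C@@H](O)[C@H]3OC4)C2=O)cc1` differs from compound 2 in one place: 4-ethoxyphenyl in place of cyclopropyl on an amine nitrogen. Going by the values given here, only one measured step bears on this exchange: a step that the two limits leave unreadable from compound 1 to compound 2. Its size cannot be read, so it offers no measured size to carry over. Among the compounds with values here, no measured compound yet carries 4-ethoxyphenyl, and neither neighbour has given a number in this assay. The data therefore support no firm direction, and the most reasonable expectation is that compound 3 remains a weak inhibitor, in the same region as the two limits. The expected change is an at least 1.3-fold lower number from compound 2 to compound 3 (0.12 log units; that floor lies within the scatter). Compound 3 is estimated at 12000 nM. The expected range for compound 3 runs from 4000 nM to 32000 nM.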

Compound 3, half-maximal inhibitory concentration: 14400 nM
Estimate against measurement, compound 3: 1.2-fold (0.08 log units) below; measured number inside the range.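

In this assay, going by these compounds alone, compound 3 gives 14400 nM, the first value at this amine nitrogen that is a number and not a limit, so 4-ethoxyphenyl, with its larger count of heavy atoms and its one hydrogen-bond acceptor, can be placed on the scale. The exchange for cyclopropyl reads as an at least 1.1-fold lower number from compound 2 to compound 3 (0.04 log units; that floor lies within the scatter), which fixes only a floor and does not separate the two compounds. The steps from compound 1 to compound 2 and from compound 1 to compound 3 cannot be read, because compound 1 is known only through a limit: the limit of > 8000 nM in this assay, at which 1 of the 3 values shown sits.

Within the data shown here, it remains open whether the ethoxy group on the phenyl ring changes the number in this assay at all, as the only compound without it has no number to set against compound 3. Also open, from the compounds shown here alone, is how a butoxy chain or a carboxylic acid in its place would read, and whether any group on this amine nitrogen can bring the number far lower.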